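The compounds below may be only part of what the source reports. "The series", "measured", "known", "first", "only" and "open" are said of these compounds alone.

Measured compounds:
- compound 1, `COc1ccccc1-c1ccc(N2CC(N3CCN(C(=O)c4ccco4)CC3)CC2=O)cc1`: 30 nM
- compound 2, `O=C(c1ccco1)N1CCN(C2CC(=O)N(c3cccc(-c4cccc(F)c4)c3)C2)CC1`: 41 nM
- compound 3, `COc1ccccc1-c1ccc(N2CC(N3CCN(c4ncccn4)CC3)CC2=O)cc1`: 72 nM

All three numbers come from an assay on isolated protein for inhibition of Monoglyceride lipase (Mus musculus), with a stated time of 30 min; on this read-out lower numbers stand for stronger inhibition and higher numbers for weaker inhibition. Compound 3 sits at the top end of these three numbers. Against compound 1 the only single-point step shown is a 2.4-fold higher number from compound 1 to compound 3 (0.38 log units; beyond the scatter), which lies beyond the scatter, so compound 3 is a modestly weaker inhibitor than compound 1. Against compound 2 the two numbers fall within the scatter of each other, so no order between compound 2 and compound 3 can be read from them.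

Compound 4 is `COc1cccc(-c2ccc(N3CC(N4CCN(c5ncccn5)CC4)CC3=O)cc2)c1`. It keeps every atom of compound 3 and only rearranges them: 3-methoxyphenyl in place of 2-methoxyphenyl on an aromatic carbon, para to a large group. No measured step touches the position of the methoxy group on this outer ring; the one step shown, from compound 1 to compound 3, concerns the other end of the molecule. Compound 1 and compound 2 differ in more than one place, so their two numbers can only be noted as lying within the scatter of each other. With nothing to anchor a direction, the expected step of a 1.1-fold higher number from compound 3 to compound 4 (0.05 log units; within the scatter) is one that stays within the scatter. Compound 4 is therefore estimated at 80 nM in this assay, with a plausible range from 30 nM to 220 nM.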

Compound 4, half-maximal inhibitory concentration: 20 nM
Compound 4: middle estimate off by 4.0-fold (0.60 log units), on the high side, and the stated range ends above it.
By their numbers in this assay, from the lowest: compounds 4, 1, 2 and 3 (each within the scatter of the next, the first and the last beyond it).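

Moving the methoxy group to a different carbon of the outer ring, without adding or removing any atom, is enough to shift the result in this assay: the step is a 3.6-fold lower number from compound 3 to compound 4 (0.56 log units; beyond the scatter). With the pyrimidin-2-yl end kept the same, 3-methoxyphenyl therefore gives stronger inhibition than 2-methoxyphenyl, a comparison that the earlier step, which concerned the other end of the molecule, could not provide. Both groups have the same heavy-atom, hydrogen-bond donor and acceptor counts, so these counts do not separate them, and no measurement shown here explains the difference.

From the compounds shown here alone, it remains open whether the same swap would give a similar step in compound 1, where the other end of the molecule carries a (furan-2-yl)carbonyl group rather than pyrimidin-2-yl. The compounds shown also leave open how other outer rings would compare with these two, such as 4-methoxyphenyl, or a phenyl ring carrying an ethoxy group or a hydroxyl group in place of the methoxy.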